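Notes on a cyanopyrrolidine series: removing the ring amide

The source may hold more compounds than are shown below. What is called first, only, known or untested is meant among the compounds shown, and "the series" means these compounds.

Measured so far:
compound 1 `N#C[C@@H]1CCCN1C(=O)[C@@H]1C[C@H](C(=O)N2CCOCC2)CN1`: 73%
compound 2 `CCN(CC)C(=O)[C@@H]1CN[C@H](C(=O)N2CCC[C@H]2C#N)C1`: 43%
compound 3 `CCNC(=O)[C@@H]1CN[C@H](C(=O)N2CCC[C@H]2C#N)C1`: 60%

In an assay on the whole organism (plasma, strain Sprague-Dawley) for inhibition of Dipeptidyl peptidase 4 (Rattus norvegicus), with a stated time of 6 h, at a dose of 1 mg/kg by the oral route (on this read-out lower numbers stand for less inhibition and higher numbers for more inhibition at the one dose given (going by the name of the read-out)), compound 3 stands second highest of the three; compound 1 is above it by a number 13 percentage points lower from compound 1 to compound 3 (beyond the scatter) and compound 2 below it by a number 17 percentage points higher from compound 2 to compound 3 (beyond the scatter). Compound 4 `N#C[C@@H]1CCCN1C(=O)[C@@H]1CCCN1` differs from compound 3 by hydrogen in place of ethylcarbamoyl on a saturated ring carbon. For the measured compounds named here, no measured step removes the group altogether; the measured steps only exchange one amide for another, by a number 30 percentage points lower from compound 1 to compound 2 (beyond the scatter), a number 13 percentage points lower from compound 1 to compound 3 (beyond the scatter) and a number 17 percentage points higher from compound 2 to compound 3 (beyond the scatter), all modest and all beyond the scatter. A whole group leaving is a larger change than any of these, so a drop beyond the scatter is expected, estimated as a number 20 percentage points lower from compound 3 to compound 4 (beyond the scatter). Compound 4 is therefore expected at about 40%, between 15% and 65%.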

Compound 4, a percentage reported as inhibition, in the whole organism at one dose (the size of the read-out at that dose, not a potency): 20%
For compound 4 the middle estimate is 20 percentage points above the measured one; the measured number falls inside the stated range.
By their numbers in this assay, from the lowest: compound 4; then compound 2; then compound 3; then compound 1.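

In this assay, the saturated ring carbon with no group at all falls short of both amides compared with it: a number 40 percentage points lower from compound 3 to compound 4 (beyond the scatter) and a number 23 percentage points lower from compound 2 to compound 4 (beyond the scatter). Even diethylcarbamoyl, the lower of these two amides, therefore stands above plain hydrogen at this position, so the earlier exchanges of one amide for another did not show the full size of the group's contribution. No evidence bearing on the cause of these drops is at hand.

Open, as far as these compounds go, is whether the amide itself matters at this carbon, or whether another group would serve as well. A carboxylic acid or a primary amine at this position would test that.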